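Adding a carboxymethyl arm to the triazole methyl of compound 1

This account rests on a few compounds, and the source may have more. Where it says the series, first, only, none or still open, it means among the compounds named here.

Measured compounds:
compound 1, `CCCCCCCCc1ccc(OCC(=O)Cn2nnc(C)n2)cc1`: 27 nM
compound 2, `CCCCCCCCc1ccc(OCC(=O)Cn2nnc(-c3cccc(Cl)c3)n2)cc1`: 24 nM
compound 3, `CCCCCCCCc1ccc(OCC(=O)Cn2nnc(-c3ccc(S(=O)(=O)N(C)C)cc3)n2)cc1`: 590 nM

All three compounds were tested in an assay on microsomes from brain for inhibition of Fatty-acid amide hydrolase 1 (Rattus norvegicus), read by fluorescence and HPLC, with a stated time of 60 min; a higher number here means a weaker inhibitor, a lower number a stronger inhibitor. Compound 1 stands second highest of the three numbers; its nearest neighbour is compound 2, with a 1.1-fold lower number from compound 1 to compound 2 (0.05 log units; within the scatter), and its furthest is compound 3, with a 22-fold higher number from compound 1 to compound 3 (1.34 log units; beyond the scatter).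

The unmeasured compound 4, `CCCCCCCCc1ccc(OCC(=O)Cn2nnc(CCC(=O)O)n2)cc1`, differs from compound 1 in one place: carboxymethyl in place of hydrogen on a saturated chain carbon bound to an aromatic carbon. The entering group brings one hydrogen-bond donor and one hydrogen-bond acceptor and no ring.

Two measured steps start from compound 1. Replacing the methyl with a 3-chlorophenyl, from compound 1 to compound 2, changed nothing beyond the scatter. Replacing it with a 4-(dimethylsulfamoyl)phenyl, from compound 1 to compound 3, gave a large rise. The change to compound 4 matches neither exactly, but it also extends the methyl with a group carrying a hydrogen-bond donor and acceptor, as the step to compound 3 did. A rise beyond the scatter is therefore expected in this assay, though smaller than for compound 3, which is estimated as a 5.6-fold higher number from compound 1 to compound 4 (0.74 log units; beyond the scatter).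

Compound 4 is estimated at 150 nM, expected to lie between 40 nM and 900 nM.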

Compound 4, half-maximal inhibitory concentration: 30 nM
Beside the measured number, compound 4's estimate is 5.0-fold (0.70 log units) above it, outside the stated range (below it).
By their numbers in this assay, from the lowest: compounds 2, 1 and 4 (each within the scatter of the next); then compound 3.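

In this assay, the numbers for the methyl of compound 1 and the 2-carboxyethyl of compound 4 cannot be told apart, with a 1.1-fold higher number from compound 1 to compound 4 (0.05 log units; within the scatter), so this position accepts a chain ending in a carboxylic acid without any loss beyond the scatter. For the compounds shown here, the same holds against the 3-chlorophenyl, with a 1.3-fold higher number from compound 2 to compound 4 (0.10 log units; within the scatter), whereas a 20-fold lower number from compound 3 to compound 4 (1.29 log units; beyond the scatter) leaves the 4-(dimethylsulfamoyl)phenyl of compound 3 as the only group here that stands apart from the rest. A group carrying a hydrogen-bond donor and a hydrogen-bond acceptor on this position is therefore not enough to give a number like that of compound 3, and a small methyl, a ring and a flexible acid chain all give values within the scatter of one another.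

Nothing available explains why these three groups give such similar numbers or why compound 3 differs. As far as these compounds go, it also remains open whether the acid itself matters here, which a methyl ester or an amine at the end of the same chain could test, and how far the position stretches, which a longer chain ending in the carboxylic acid could show.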